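Trifluoromethyl in Place of Methyl on the Aromatic Ring

This account rests on a few compounds, and the source may have more. Where it says the series, first, only, none or still open, it means among the compounds named here.

Of the compounds shown here, three that share one core have been tested in a functional assay on the whole organism with Rattus norvegicus as the target; on this read-out lower numbers stand for an effect already at smaller amounts and higher numbers for an effect only at larger amounts of compound. Compound 1 `CC1CCC(/C=N/c2ccc(F)cc2)=C2NC=C(C(=O)O)C(=O)N21` gives 10.6 umol/kg. Compound 2 `CC1CCC(/C=N/c2ccc(O)cc2)=C2NC=C(C(=O)O)C(=O)N21` gives 1.2 umol/kg, and the change from fluoro to hydroxy on an aromatic carbon brings an 8.8-fold lower number from compound 1 to compound 2 (0.95 log units; beyond the scatter). Compound 3 `Cc1ccc(/N=C/C2=C3NC=C(C(=O)O)C(=O)N3C(C)CC2)cc1` gives 3.6 umol/kg, which places it second highest of the three numbers: it sits between the other two, with a 2.9-fold lower number from compound 1 to compound 3 (0.47 log units; beyond the scatter) and a 3.0-fold higher number from compound 2 to compound 3 (0.48 log units; beyond the scatter), both steps beyond the scatter but modest in size.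

Compound 4 `CC1CCC(/C=N/c2ccc(C(F)(F)F)cc2)=C2NC=C(C(=O)O)C(=O)N21` has not yet been measured. It differs from compound 3 in one place: trifluoromethyl in place of methyl on an aromatic carbon. Within the data shown here, none of the measured steps puts a trifluoromethyl onto this ring, so there is no direct guide. The two steps that do touch the same aromatic carbon both ended at compound 3 and were each of modest size in opposite directions, which shows that a change at this position can move the number either way. Given this, a modest shift is expected for compound 4, with the direction uncertain, as a 2.2-fold higher number from compound 3 to compound 4 (0.35 log units; beyond the scatter). The estimate for compound 4 in this assay is therefore 8 umol/kg, with a range from 2.5 umol/kg to 25 umol/kg.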

Compound 4, dose for 50% inhibition: > 100 umol/kg
Compound 4 was reported as a limit (the forecaster's own chance of this, stated with the estimate: 10%); at least 12-fold (1.09 log units) between middle value and limit.
By their numbers in this assay, from the lowest: compound 2; then compound 3; then compound 1. At a limit, above all of these: compound 4.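

In this assay compound 4 is recorded only as a limit and not as a number: the limit of > 100 umol/kg in this assay, at which 1 of the 4 values shown sits. Among these compounds, until now, fluoro, hydroxy and methyl on this aromatic carbon had kept all three printed numbers fairly close together, and trifluoromethyl is the first group here to take the number out of that range, whichever earlier compound it is compared with: methyl to trifluoromethyl gives the largest single change seen on this ring from its nearest analogue in shape (an at least 27-fold higher number from compound 3 to compound 4 (1.44 log units; beyond the scatter)), hydroxy to trifluoromethyl gives the widest gap (an at least 83-fold higher number from compound 2 to compound 4 (1.92 log units; beyond the scatter)), and fluoro to trifluoromethyl gives the smallest of the three but still a clear one (an at least 9.4-fold higher number from compound 1 to compound 4 (0.97 log units; beyond the scatter)). So this position does not accept every small group equally, and swapping one carbon-bearing group for another with three fluorines on that carbon is enough to lose the effect up to the limit of the test.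

What the compounds shown leave open is how other groups on this carbon would behave, such as an amine, a carboxylic acid or a longer chain. They also give no way to tell what in the trifluoromethyl group lies behind this result.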